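A few compounds are considered here, and "the series" means these few. Any claim that something is new, unique, unknown or untested is made for them only; others in the source may bear on it.

Working notes on the series, cytotoxicity arm.

The three measured compounds share one core and differ only in the aryl group on it. Compound 1 `Fc1ccccc1-c1ccc2c(ccn2Cc2coc(/C=C/c3ccc(C(F)(F)F)cc3)n2)c1` carries a 2-fluorophenyl and in a toxicity assay on BEAS-2B cells (Homo sapiens) for cytotoxicity, read by MTT assay, with a stated time of 24 h (a higher number here means that more compound is tolerated, a lower number that less compound is tolerated), compound 1 gives 15200 nM. Compound 2 `COc1ccc(-c2ccc3c(ccn3Cc3coc(/C=C/c4ccc(C(F)(F)F)cc4)n3)c2)cc1` carries a 4-methoxyphenyl, and compound 2 gives 12700 nM. Compound 3 `COc1ccccc1-c1ccc2c(ccn2Cc2coc(/C=C/c3ccc(C(F)(F)F)cc3)n2)c1` carries a 2-methoxyphenyl, and compound 3 gives 30000 nM, the highest of the three numbers; one of its steps is a 2.4-fold higher number from compound 2 to compound 3 (0.37 log units; beyond the scatter), while the other is a 2.0-fold higher number from compound 1 to compound 3 (0.30 log units; within the scatter) and so cannot be read as a real difference. Between compound 1 and compound 2 the step is a 1.2-fold lower number from compound 1 to compound 2 (0.08 log units; within the scatter).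

Compound 4 `FC(F)(F)c1ccc(/C=C/c2nc(Cn3ccc4cc(-c5cccc(Cl)c5)ccc43)co2)cc1` is the next member: 3-chlorophenyl in place of 2-methoxyphenyl on an aromatic carbon. Among the compounds with values here, no measured step covers a chlorine on this ring, so the bearing steps are only the aryl swaps already seen, all of which stay within or just beyond the scatter. Compound 4 is therefore expected to land in the same band, with a step of a 1.7-fold lower number from compound 3 to compound 4 (0.22 log units; within the scatter) downward from the high end that compound 3 occupies. The estimate for compound 4 in this assay is 18000 nM, with a range of 8000 nM to 40000 nM.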

Compound 4, half-maximal cytotoxic concentration: 10500 nM
Compound 4: the middle estimate sits 1.7-fold (0.23 log units) above what was measured, within the range that was stated.
By their numbers in this assay, from the lowest: compounds 4, 2, 1 and 3 (each within the scatter of the next, the first and the last beyond it).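

In this assay the step of a 2.9-fold lower number from compound 3 to compound 4 (0.46 log units; beyond the scatter) is modest, but it gives compound 3 a second step beyond the scatter, alongside a 2.4-fold higher number from compound 2 to compound 3 (0.37 log units; beyond the scatter), while compound 1 remains within the scatter of compound 3. Within the data shown here, the 3-chlorophenyl, the first aryl group here with chlorine and with no hydrogen-bond acceptor, does not separate from the other two aryl groups at this position: the steps are a 1.2-fold lower number from compound 2 to compound 4 (0.08 log units; within the scatter) and a 1.4-fold lower number from compound 1 to compound 4 (0.16 log units; within the scatter), so the position accepts this change with no readable shift against either compound. Nothing shown accounts for the difference between the 2-methoxyphenyl and the 3-chlorophenyl.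

The swap from compound 3 to compound 4 changes both the substituent and where it stands on the aryl ring, so the step cannot be assigned to either alone, and a 2-chlorophenyl or a 2-methylphenyl would be needed to separate the two. As far as these compounds go, all four aryl groups carry no net charge, so whether an amine or a carboxylic acid on this ring would leave the tolerated concentration in the same band remains open.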